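Moving the Bromine on the Phenyl Ring of Compound 3

The source may hold more compounds than are shown below. What is called first, only, known or untested is meant among the compounds shown, and "the series" means these compounds.

Of the compounds shown here, three have been measured in a functional assay on HL-60 cells (Homo sapiens) for antiproliferative activity, read by sulforhodamine B assay, with a stated time of 72 h; a higher number here means a weaker inhibitor, a lower number a stronger inhibitor. Compound 1 `NC(=S)N/N=C/c1cc2cccnc2s1` returns only a limit there, > 100000 nM. Of the two true numbers, compound 2 `N#Cc1ccc(NC(=S)N/N=C/c2ccc3ccccc3n2)cc1` gives 4660 nM, while compound 3 `S=C(N/N=C/c1ccc2ccccc2n1)Nc1cccc(Br)c1` gives 53800 nM, the higher of the pair and so the weaker inhibitor. Among the compounds with values here, the one measured step joining them is a 12-fold higher number from compound 2 to compound 3 (1.06 log units; beyond the scatter), a large change beyond the scatter, with 3-bromophenyl in place of 4-cyanophenyl on an amide-type nitrogen.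

Compound 4 `S=C(N/N=C/c1ccc2ccccc2n1)Nc1ccccc1Br` has the same atoms as compound 3, joined differently: 2-bromophenyl in place of 3-bromophenyl on an amide-type nitrogen. It carries 2-bromophenyl in place of 3-bromophenyl on that same nitrogen. Within the data shown here, no measured step shows this kind of change directly. The nearest guide is a 12-fold higher number from compound 2 to compound 3 (1.06 log units; beyond the scatter), which shows that one replacement at this place moved the number strongly, but it exchanged a different group. As far as these compounds go, with compound 3 already at 53800 nM, a moderate fall is expected rather than a rise, though either direction remains open. The expected step is a 2.2-fold lower number from compound 3 to compound 4 (0.33 log units; beyond the scatter), smaller than the measured one. For compound 4 the estimated value in this assay is 25000 nM, with an expected range from 6000 nM to 90000 nM.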

Compound 4, half-maximal inhibitory concentration: > 100000 nM
Compound 4: no number, only a limit; the forecaster's own chance of this, stated with the estimate: 12%; at least 4.0-fold (0.60 log units) between middle value and limit.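

Moving the bromine, with 2-bromophenyl in place of 3-bromophenyl on the amide-type nitrogen, gives an at least 1.8-fold higher number from compound 3 to compound 4 (0.26 log units; that floor lies within the scatter) in this assay. Within the data shown here, the earlier compounds showed only that exchanging one group for another at this nitrogen could move the number strongly, whereas this pair keeps the atoms the same and changes only how they are joined; taken by itself, however, the floor of this step does not establish a change beyond the scatter. Measured against the 4-cyanophenyl group, the new compound gives an at least 21-fold higher number from compound 2 to compound 4 (1.33 log units; beyond the scatter), which places it with compound 3 on the weaker side of compound 2, as a 12-fold higher number from compound 2 to compound 3 (1.06 log units; beyond the scatter) already did for the 3-bromophenyl group, and the reading for compound 4 is a limit and not a number: the limit of > 100000 nM in this assay, at which 2 of the 4 values shown sit.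

As far as these compounds go, how far the true value of compound 4 lies from that of compound 3 therefore stays unknown, so the full size of the shift cannot be stated. The compounds shown also leave open how a methoxy group or an amine would read in place of the bromine on this phenyl ring.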